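Amide ring variation on the sulfonyl piperazine core

The source may hold more compounds than are shown below. What is called first, only, known or untested is meant among the compounds shown, and "the series" means these compounds.

Measured compounds:
- compound 1 `CC(C(=O)N1CC2CC2C1)N1CCN(S(=O)(=O)c2ccc(C(C)(C)C)cc2)CC1`: > 40000 nM in an ADME assay on HepG2 cells (Homo sapiens) for inhibition, with a stated time of 48 h; a higher number here means that more compound is needed for the effect, a lower number that less compound is needed (a limit of the assay)
- compound 2 `CC(C(=O)N1CCC2(CC1)CC2)N1CCN(S(=O)(=O)c2ccc(C(C)(C)C)cc2)CC1`: > 40000 nM (a limit of the assay)
- compound 3 `CC(C(=O)N1CCc2ccccc2C1C)N1CCN(S(=O)(=O)c2ccc(C(C)(C)C)cc2)CC1`: 28000 nM

Compound 1 sits at the limit in this assay, so only a bound is known for it; compound 2 sits at the same limit (the limit of > 40000 nM in this assay, at which 2 of the 3 values shown sit). Going by the values given here, compound 3 is the only compound with a number. The step that the two limits leave unreadable from compound 1 to compound 2 is unreadable; the steps of an at least 1.4-fold lower number from compound 1 to compound 3 (0.15 log units; that floor lies within the scatter) and an at least 1.4-fold lower number from compound 2 to compound 3 (0.15 log units; that floor lies within the scatter) have floors that lie within the scatter, so no change beyond the scatter is secured anywhere in the series.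

Compound 4 `CC(C(=O)N1CCc2cccnc2C1)N1CCN(S(=O)(=O)c2ccc(C(C)(C)C)cc2)CC1` carries a group of 10 heavy atoms (8 carbon, 2 nitrogen; one six-membered non-aromatic ring with 1 hetero atom, one six-membered aromatic ring with 1 hetero atom) in place of a group of 6 heavy atoms (5 carbon, 1 nitrogen; one three-membered non-aromatic ring of carbon only, one five-membered non-aromatic ring with 1 hetero atom), on a carbonyl carbon. Among the compounds with values here, the nearest measured step is the one to compound 3, which also places a six-membered non-aromatic ring with one hetero atom fused to a six-membered aromatic ring on the carbonyl carbon; that step was at most modest. The expected step of a number no higher from compound 1 to compound 4 (the limit leaves the size open) is therefore none beyond the scatter, and compound 4 is estimated at 40000 nM (range 15000 nM to 100000 nM), with a substantial chance that only the limit is reported.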

Compound 4, half-maximal effective concentration: > 40000 nM
Compound 4: only a limit was reported; the forecaster's own chance of this, stated with the estimate: 60%; the middle value sits exactly at the limit.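

In this assay compound 4 gives > 40000 nM and this is a limit of the assay, so a six-membered aromatic ring with 1 hetero atom in the group on the carbonyl carbon does not yield a number here. Going by these compounds alone, the one readable step, an at least 1.4-fold higher number from compound 3 to compound 4 (0.15 log units; that floor lies within the scatter), secures no change beyond the scatter between this group and the group of compound 3 with its six-membered aromatic ring of carbon only. The steps from compound 1 and compound 2 to compound 4 cannot be read, and the limit now covers most of the series: the limit of > 40000 nM in this assay, at which 3 of the 4 values shown sit.

The compounds shown leave open whether any group on this carbonyl carbon moves the number beyond the scatter. A carboxylic acid or an amine on the six-membered aromatic ring remains an open case.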